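A few compounds are considered here, and "the series" means these few. Any claim that something is new, unique, unknown or untested is made for them only; others in the source may bear on it.

Measured so far:
- compound 1 `CCC(Nc1ccc(S(=O)(=O)Nc2nccs2)cc1Cl)c1ccccc1` in an assay on HEK293 cells for inhibition of SCN8A/SCN1B (Homo sapiens), read by patch clamp, with a stated time of 20 min (on this read-out higher numbers stand for weaker inhibition and lower numbers for stronger inhibition), gives 50 nM
- compound 2 `CC(Nc1ccc(S(=O)(=O)Nc2nccs2)cc1Cl)c1ccccc1` in this assay gives 100 nM

Among the measured compounds shown here, on these two numbers compound 2 has the higher one, yet the only known step, a 2.0-fold higher number from compound 1 to compound 2 (0.30 log units; within the scatter), stays within the scatter, so the two cannot be ranked. Compound 3 `C[C@@H](Nc1ccc(S(=O)(=O)Nc2nccs2)cc1Cl)c1ccccc1` differs from compound 2 by the two compounds have the same atoms and bonds; at least one stereo element is drawn with a configuration in one of them and without one in the other: 1 of 1 stereo elements differ; a stereocentre at a saturated chain carbon is drawn without a configuration in compound 2 and R in compound 3; compound 2 is thus a mixture of both mirror forms, compound 3 a single one. For the measured compounds named here, no measured step bears on such a separation. If either mirror form carries the activity, the expected step is a 1.3-fold lower number from compound 2 to compound 3 (0.10 log units; within the scatter), with wide uncertainty. Compound 3 is therefore estimated at 80 nM, ranging from 30 nM to 400 nM.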

Compound 3, half-maximal inhibitory concentration in the SCN8A/SCN1B assay: 620 nM
The estimate for compound 3 lay 7.8-fold (0.89 log units) below the measured number; the measured number lies above the stated range.
By their numbers in the SCN8A/SCN1B assay, from the lowest: compounds 1 and 2 (each within the scatter of the next); then compound 3.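

Among the compounds shown here, in the SCN8A/SCN1B assay the configuration at this saturated chain carbon proves to matter, which the earlier compounds could not show, as compound 2 gives 100 nM and compound 3 gives 620 nM: a 6.2-fold higher number from compound 2 to compound 3 (0.79 log units; beyond the scatter). Compound 2 holds both mirror forms and compound 3 only the R form, so the R form alone does not account for the activity of the mixture, which points to the other mirror form. In a physicochemical assay for lipophilicity, read by LC-MS, in phosphate buffer, measured as octanol-water partition, with a stated time of 1 h, at pH 7.4 (on this read-out lower numbers stand for lower lipophilicity and higher numbers for higher lipophilicity), compound 2 gives 3.2 and compound 3 gives 3.2, so the same change gives no change at the digits printed from compound 2 to compound 3 (within the scatter) and the structures offer a single difference to go with the gap in inhibition: the fact that one of compounds 2 and 3 is drawn with a defined configuration and the other without, at the place where they differ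

Still open, as far as these compounds go, are the number for the S form on its own, and whether a longer chain or a hydroxyl group on this carbon would show the same sensitivity to configuration.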